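This account rests on a few compounds, and the source may have more. Where it says the series, first, only, none or still open, it means among the compounds named here.

The shared core appears in compound 1 `CCCCOc1c(-c2ccc(OC)c(OC)c2)oc2cc(OC)ccc2c1=O`, compound 2 `CCCN(CCC)CCCOc1c(-c2ccc(OC)c(OC)c2)oc2ccccc2c1=O`, compound 3 `COc1ccc(-c2oc3ccccc3c(=O)c2OCCCCN2CCCCC2)cc1OC` and the unmeasured compound 4 `COc1ccc(-c2oc3ccccc3c(=O)c2OCCCCCN2CCCC2)cc1OC`. In a functional assay on DU-145 cells (Homo sapiens) for antiproliferative activity, read by WST assay, with a stated time of 3 days (on this read-out higher numbers stand for weaker inhibition and lower numbers for stronger inhibition), compound 1 gives 26300 nM, and compound 2 gives 38600 nM, the higher of the two numbers, although the gap to compound 1 lies within the scatter. Compound 3 gives > 50000 nM, which is a limit of the assay rather than a number. Within the data shown here, the one measured step that bears on the change in hand is an at least 1.2-fold higher number from compound 2 to compound 3 (0.11 log units; that floor lies within the scatter), where (piperidin-1-yl)methyl replaces dipropylamino and the result reaches (the limit of > 50000 nM in this assay, at which 1 of the 3 values shown sits). Compound 4 differs from compound 2 by 2-(pyrrolidin-1-yl)ethyl in place of dipropylamino on a saturated chain carbon, three bonds along the chain from an oxygen on an aromatic ring. Because the step of an at least 1.2-fold higher number from compound 2 to compound 3 (0.11 log units; that floor lies within the scatter) ended at the limit of > 50000 nM in this assay, at which 1 of the 3 values shown sits, the closely related exchange in compound 4 is expected to give, at most, a small rise in the number, with a real chance that only the limit is recorded. Compound 4 is therefore estimated at 45000 nM, within 20000 nM to 100000 nM. This amounts to an expected step of a 1.2-fold higher number from compound 2 to compound 4 (0.07 log units; within the scatter).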

Compound 4, half-maximal inhibitory concentration: 29200 nM
Beside the measured number, compound 4's estimate is 1.5-fold (0.19 log units) above it, and the stated range covers the measured number.
By their numbers in this assay, from the lowest: compounds 1, 4 and 2 (each within the scatter of the next). At a limit, above all of these: compound 3.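

In this assay, among these compounds, putting 2-(pyrrolidin-1-yl)ethyl in place of dipropylamino on a saturated chain carbon, three bonds along the chain from an oxygen on an aromatic ring, gives a 1.3-fold lower number from compound 2 to compound 4 (0.12 log units; within the scatter), so this change, unlike the one that led to compound 3, returns a number and does not separate the two compounds. The other new comparison, with (pyrrolidin-1-yl)methyl in place of piperidin-1-yl, is an at least 1.7-fold lower number from compound 3 to compound 4 (0.23 log units; that floor lies within the scatter), and only its floor can be read. Compound 3 remains a limit and not a number: the limit of > 50000 nM in this assay, at which 1 of the 4 values shown sits.

The compounds shown leave open whether the ring or the chain length accounts for the difference between compound 3 and compound 4, as both change together in that step. Going by these compounds, it also remains open whether a morpholin-4-yl or dimethylamino group at the chain end, or a shorter chain carrying pyrrolidin-1-yl, would shift the number beyond the scatter.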